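1H-pyrrol-2-yl Replaces Hexyl on a Shared Core

This account rests on a few compounds, and the source may have more. Where it says the series, first, only, none or still open, it means among the compounds named here.

Of the compounds shown here, three built on one shared core have been measured so far in a functional assay on cells (Erythrocyte, Homo sapiens) for inhibition, read by spectrophotometry and hemolysis, with a stated time of 10 min (on this read-out higher numbers stand for weaker inhibition and lower numbers for stronger inhibition), as the test. There compound 1 (`Cc1ccc(/C=N\Nc2nc3cccc(C)c3s2)cc1`) gives 54.3 ug/mL and compound 2 (`Cc1cccc2nc(N/N=C\c3ccc(O)cc3O)sc12`) gives 58.2 ug/mL as its value. Compound 3 (`CCCCCC/C=N/Nc1nc2cccc(C)c2s1`) gives 82.2 ug/mL on the same scale, a number within the usual scatter of both others, so it is not set apart from them.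

Compound 4 (`Cc1cccc2nc(N/N=C/c3ccc[nH]3)sc12`) awaits measurement. It differs from compound 3 in one place, with 1H-pyrrol-2-yl in place of hexyl on a carbon with a double bond to nitrogen. Within the data shown here, no measured pair shows this exact change. However, the group on that carbon also differs among the three tested compounds, and compound 1 at 54.3 ug/mL and compound 3 at 82.2 ug/mL stay within the scatter. In this assay the expected 1.3-fold lower number from compound 3 to compound 4 (0.12 log units; within the scatter) is therefore no step beyond the scatter. Compound 4 is estimated at 62 ug/mL with an expected range from 35 ug/mL to 105 ug/mL as its bounds.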

Compound 4, half-maximal inhibitory concentration: 46.2 ug/mL
For compound 4 the middle estimate is 1.3-fold (0.13 log units) above the measured one; measured number inside the range.
By their numbers in this assay, from the lowest: compounds 4, 1, 2 and 3 (each within the scatter of the next).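

In this assay, among these compounds, placing 1H-pyrrol-2-yl in place of hexyl on a carbon with a double bond to nitrogen gives a 1.8-fold lower number from compound 3 to compound 4 (0.25 log units; within the scatter) and provides the first direct comparison in which only this group differs. An open hexyl chain and a five-membered aromatic ring with a hydrogen-bond donor can therefore occupy this place without a difference that stands clear of the scatter. Nothing measured here speaks to what either group contributes to the result.

The compounds shown leave open whether any group at this place can shift the number beyond the scatter. As far as these compounds go, how a carboxylic acid, an amine or a chain longer than hexyl would read there also remains unknown, as does whether the hydrogen on the nitrogen of the new ring matters.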